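Adding Fluorine to the Phenyl Ring of Compound 2

The compounds below may be only part of what the source reports. "The series", "measured", "known", "first", "only" and "open" are said of these compounds alone.

Of the compounds shown here, two have been measured in a functional assay on cardiac atrium for agonist activity at histamine H2 receptor (Cavia porcellus); a higher number here means a more potent compound, by a factor of ten per unit of this negative logarithm, a lower number a less potent compound. Compound 1 `N=C(NCCCc1c[nH]cn1)NCCSC(c1ccccc1)c1ccccn1` gives 6.6 in this assay, and compound 2 `N=C(NCCCc1c[nH]cn1)NCCCC(c1ccccc1)c1ccccn1` gives 6.61. Numerically compound 2 is the higher of the two numbers, but the gap to its nearest neighbour, compound 1, falls within the scatter of repeated measurements, so the two cannot be distinguished on these data, and no step between measured compounds is available to guide the next prediction.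

Compound 3 `N=C(NCCCc1c[nH]cn1)NCCCC(c1ccc(F)cc1)c1ccccn1` differs from compound 2 by a single change: fluoro in place of hydrogen on an aromatic carbon of a six-membered aromatic ring of carbon only, para to a large group, so that phenyl becomes 4-fluorophenyl. Within the data shown here, with no measured step to draw on and the two known values sitting together, the expected step in this assay is a number 0.01 log units lower from compound 2 to compound 3 (within the scatter), nothing beyond the usual scatter in either direction. Compound 3 is therefore estimated at 6.6, with a range from 6.2 to 7.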

Compound 3, negative logarithm of the half-maximal effective concentration: 6.87
For compound 3 the middle estimate is 0.27 log units below the measured one, and the stated range covers the measured number.
By their numbers in this assay, from the lowest: compounds 1, 2 and 3 (each within the scatter of the next).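

In this assay, among these compounds, the change from phenyl to 4-fluorophenyl gives a number 0.26 log units higher from compound 2 to compound 3 (within the scatter), the first step that can be read from one change in one place. It shows that fluoro can stand in place of hydrogen on this aromatic carbon, para to a large group, without a difference that can be told from the usual variation between repeated measurements, so compound 3 and compound 2 cannot be separated on these data. Nothing available here bears on what lies behind this result.

A single step at a single position leaves open whether a larger group, such as chloro, methoxy or trifluoromethyl, or a group of another kind, such as an amine or a carboxylic acid, would be accommodated at this carbon in the same way, and whether a step beyond the scatter would appear with any of them. It also leaves open how fluoro would read on the other carbons of this ring, and whether the same change on the phenyl of compound 1 would give a similar step.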